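The compounds below may be only part of what the source reports. "The series", "measured", "known", "first", "only" and "open" are said of these compounds alone.

In an assay on CHO cells for antagonist activity at transient receptor potential cation channel subfamily V member 1 (Homo sapiens), read by FLIPR (on this read-out higher numbers stand for weaker inhibition and lower numbers for stronger inhibition), compound 2 `CC(C(=O)NCc1ccc(C(F)(F)F)nc1-c1cccc(Cl)c1)c1ccc(NS(C)(=O)=O)c(F)c1` gives 0.5 nM; compound 1 `CC(C(=O)NCc1ccc(C(F)(F)F)nc1-c1ccc(Cl)cc1)c1ccc(NS(C)(=O)=O)c(F)c1` gives 0.7 nM; compound 3 `CC(C(=O)NCc1ccc(C(F)(F)F)nc1-c1ccsc1)c1ccc(NS(C)(=O)=O)c(F)c1` gives 2 nM.

Among these three, compound 2 has the lowest number, though the gap to compound 1, a 1.4-fold lower number from compound 1 to compound 2 (0.15 log units; within the scatter), is within the scatter, and only the gap to compound 3, a 4.0-fold higher number from compound 2 to compound 3 (0.60 log units; beyond the scatter), lies beyond it. Compound 4 `CC(C(=O)NCc1ccc(C(F)(F)F)nc1C#Cc1ccccc1)c1ccc(NS(C)(=O)=O)c(F)c1` differs from compound 2 in one place: 2-phenylethynyl in place of 3-chlorophenyl on an aromatic carbon. The measured steps that bear on this change are a 1.4-fold lower number from compound 1 to compound 2 (0.15 log units; within the scatter), a 2.9-fold higher number from compound 1 to compound 3 (0.46 log units; beyond the scatter) and a 4.0-fold higher number from compound 2 to compound 3 (0.60 log units; beyond the scatter); the latter two show that giving up the chlorophenyl costs a modest amount. Because 2-phenylethynyl departs further from 3-chlorophenyl than thiophen-3-yl does in a 4.0-fold higher number from compound 2 to compound 3 (0.60 log units; beyond the scatter), a modest weakening is expected, a 6.0-fold higher number from compound 2 to compound 4 (0.78 log units; beyond the scatter). Compound 4 is therefore estimated at 3 nM, within a range of 0.7 nM to 15 nM.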

Compound 4, inhibition constant: 0.8 nM
Compound 4: the middle estimate sits 3.8-fold (0.57 log units) above what was measured; the range from low to high includes it.
By their numbers in this assay, from the lowest: compounds 2, 1 and 4 (each within the scatter of the next); then compound 3.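

At this position next to the ring nitrogen, a triple bond can stand before the phenyl ring without a change beyond the scatter in this assay: a 1.6-fold higher number from compound 2 to compound 4 (0.20 log units; within the scatter) and a 1.1-fold higher number from compound 1 to compound 4 (0.06 log units; within the scatter). The same group does separate itself from thiophen-3-yl, with a 2.5-fold lower number from compound 3 to compound 4 (0.40 log units; beyond the scatter). No data here explain these results. The compounds shown leave open whether a chlorine on the phenyl ring of 2-phenylethynyl would keep the number this low. They also leave open how a saturated chain or an amine such as morpholine would fare at this position.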